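Swapping an Anilino Amide for a Diethylamino Amide

The source may report more compounds than this note shows. Statements on the series, on what has been measured and on what is new or still open speak of the compounds shown alone.

Compound 1 `COc1ccc(C[C@H]2COC(=O)[C@@H]2Cc2ccc(OCC(=O)Nc3ccccc3)c(OC)c2)cc1OC` was tested in an ADME assay on HeLa cells (Homo sapiens) for cytotoxicity, read by MTT assay; on this read-out higher numbers stand for weaker inhibition and lower numbers for stronger inhibition. For compound 1 the result is a limit of the assay rather than a number, >= 600000 nM. Compound 2 `COC(=O)[C@@H](NC(=O)CCC(=O)Oc1ccc(C[C@H]2C(=O)OC[C@@H]2Cc2ccc(OC)c(OC)c2)cc1OC)c1c[nH]c2ccccc12` likewise reaches only a limit, >= 600000 nM. Compound 3 `COc1ccc(-n2cc(COc3ccc(C[C@H]4C(=O)OC[C@@H]4Cc4ccc(OC)c(OC)c4)cc3OC)nn2)cc1` also gives a limit, >= 600000 nM. Every value shown thus sits at the limit of >= 600000 nM in this assay, at which 3 of the 3 values shown sit, and compound 1 stands level with the other two. The unmeasured compound 4 `CCN(CC)C(=O)COc1ccc(C[C@H]2C(=O)OC[C@@H]2Cc2ccc(OC)c(OC)c2)cc1OC` differs from compound 1 in one place: diethylamino in place of anilino on a carbonyl carbon. No measured step connects any two of these compounds, so no change beyond the scatter is expected. The step is estimated as a number no higher from compound 1 to compound 4 (the limit leaves the size open). Compound 4 is expected to give 600000 nM, probably again a limit, within 300000 nM to 1200000 nM.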

Compound 4, half-maximal inhibitory concentration: 188000 nM
For compound 4 the middle estimate is 3.2-fold (0.50 log units) above the measured one; measured number below the stated range.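

In this assay, this carbonyl carbon proves sensitive to what it carries, with diethylamino in place of anilino giving an at least 3.1-fold lower number from compound 1 to compound 4 (0.50 log units; beyond the scatter). A lower number here stands for stronger inhibition, so compound 4 is more cytotoxic to these cells than compound 1, and it alone yields a number rather than a limit: the limit of >= 600000 nM in this assay, at which 3 of the 4 values shown sit.

The change removes the aromatic ring and the hydrogen-bond donor together, and the compounds shown cannot separate the two. Going by these compounds, how a cyclohexylamino group or a piperidine on this carbonyl carbon would read stays open.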